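The compounds below may be only part of what the source reports. "The series", "measured", "known", "first", "only" and "open" are said of these compounds alone.

Compound 1 `CCCCn1nc(C)c(C(=O)OC)c1Cc1ccc(-c2ccccc2-c2nn[nH]n2)cc1` was run in a functional assay on the whole organism for inhibition, with Rattus norvegicus as the target, at a dose of 3 mg/kg (on this read-out lower numbers stand for less inhibition and higher numbers for more inhibition at the one dose given (going by the name of the read-out)), and in that test compound 1 gives 52.5%. Among the compounds with values here, of the two numbers so far this is the lowest: compound 2 `CCCn1nc(CC)c(C(=O)O)c1Cc1ccc(-c2ccccc2-c2nn[nH]n2)cc1` gives 82.9%, a figure that lies higher by more than the usual scatter. Within the data shown here, the two measured compounds differ in several places at once, so no step of known size between them can be read off. Compound 3 `CCCCn1nc(C)c(CO)c1Cc1ccc(-c2ccccc2-c2nn[nH]n2)cc1` has not yet been measured. It departs from compound 1 in one place: hydroxymethyl in place of methoxycarbonyl on an aromatic carbon. The measured pair says nothing about how a change of this kind moves the read-out, so the expectation rests on compound 1 alone. The step is expected to be small, a number 4.5 percentage points higher from compound 1 to compound 3 (within the scatter), not beyond the scatter in either direction. Compound 3 is estimated at 57% in this assay, with a range from 35% to 80%.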

Compound 3, a percentage reported as inhibition, in the whole organism at one dose (the size of the read-out at that dose, not a potency): 11.5%
Compound 3: the middle estimate sits 45.5 percentage points above what was measured, outside the stated range (below it).
By their numbers in this assay, from the lowest: compound 3; then compound 1; then compound 2.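

In this assay, hydroxymethyl in place of methoxycarbonyl on this aromatic carbon gives a number 41 percentage points lower from compound 1 to compound 3 (beyond the scatter) and so marks this position as one where the choice of group matters greatly. Within the data shown here, this is the first step in the set that can be read at a single place, which the two earlier compounds, differing in several places at once, could not provide. The change removes the carbonyl, shortens the group to fewer heavy atoms and adds a hydrogen-bond donor, and nothing available explains why the number moves so far.

The compounds shown leave open which of these differences carries the step, as they include no amide, nitrile or aldehyde on this carbon of the core of compound 1. They also leave open whether an ethyl ester there would stay close to compound 1 in this assay or move away from it.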